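Trimming the isopropoxy chain: from compound 1 to compound 4

A few compounds are considered here, and "the series" means these few. Any claim that something is new, unique, unknown or untested is made for them only; others in the source may bear on it.

Compound 1 `Cc1cc(C)c(CNC(=O)c2cccc(OC(C)C)c2C)c(=O)[nH]1`: 1400 nM
Compound 2 `Cc1cc(C)c(CNC(=O)c2cccc(OC(C)C)c2Cl)c(=O)[nH]1`: 1300 nM
Compound 3 `COc1cccc(C(=O)NCc2c(C)cc(C)[nH]c2=O)c1`: > 150000 nM

In an assay on Sf9 cells for inhibition of histone-lysine N-methyltransferase EZH2 (Homo sapiens), read by scintillation counting, with a stated time of 60 min, in the presence of a further agent that is not named here (a higher number here means a weaker inhibitor, a lower number a stronger inhibitor), compound 1 gives 1400 nM, the higher of the two plain numbers, but its nearest neighbour compound 2 sits at 1300 nM, a gap of a 1.1-fold lower number from compound 1 to compound 2 (0.03 log units; within the scatter) that falls within the scatter. Compound 3 gives only a limit, > 150000 nM, which is the edge of what the assay reports rather than a number (the limit of > 150000 nM in this assay, at which 1 of the 3 values shown sits).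

Compound 4 `CCOc1cccc(C(=O)NCc2c(C)cc(C)[nH]c2=O)c1C` differs from compound 1 by hydrogen in place of methyl on a saturated chain carbon bound to an oxygen on an aromatic ring and a saturated chain carbon; read one bond further out, the isopropoxy becomes an ethoxy. Among the measured compounds shown here, no measured step touches this chain: the only step on record, chloro for methyl on the aromatic carbon, changed the number by a 1.1-fold lower number from compound 1 to compound 2 (0.03 log units; within the scatter), within the scatter. A small loss of the chain is therefore expected to move the number at most modestly upward. For compound 4 the estimate is 2500 nM, between 1000 nM and 7000 nM, a step of a 1.8-fold higher number from compound 1 to compound 4 (0.25 log units; within the scatter).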

Compound 4, half-maximal inhibitory concentration: 2000 nM
Compound 4: middle estimate off by 1.3-fold (0.10 log units), on the high side; low and high end bracket the measured number.
By their numbers in this assay, from the lowest: compounds 2, 1 and 4 (each within the scatter of the next). At a limit, above all of these: compound 3.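

In this assay, cutting isopropoxy back to ethoxy gives a 1.4-fold higher number from compound 1 to compound 4 (0.15 log units; within the scatter), so the two chains cannot be told apart here. Among the compounds shown here, this is the first measured change on the chain itself, and it shows that the methyl on the saturated chain carbon bound to an oxygen on an aromatic ring can go without a step beyond the scatter. Nothing measured here bears on why this methyl makes so little difference.

Still open, on these data alone, is how far this tolerance reaches: whether a longer chain such as butoxy, a ring such as cyclopentyloxy, or an amine at the end of the chain would stay within the scatter of compound 4. Also open, as far as these compounds go, is whether ethoxy behaves the same way with chloro on the aromatic carbon in place of methyl.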